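Compound 3 to compound 4: methoxy for dimethylamino

The source may report more compounds than this note shows. Statements on the series, on what has been measured and on what is new or still open speak of the compounds shown alone.

In a functional assay (trachea) with Cavia porcellus as the target (on this read-out lower numbers stand for an effect already at smaller amounts and higher numbers for an effect only at larger amounts of compound), compound 1 (`C=CCn1c(=O)c2[nH]cnc2n(CCC)c1=O`) gives 1600 nM. In the same read-out compound 2 (`CCCn1c(=O)n(CC(=O)O)c(=O)c2[nH]cnc21`) gives 41000 nM, and compound 3 (`CCCn1c(=O)n(CCN(C)C)c(=O)c2[nH]cnc21`) gives 2700 nM. Compound 3 therefore stands with the lower pair of numbers: the nearest step is a 1.7-fold higher number from compound 1 to compound 3 (0.23 log units; within the scatter), and the largest step reaching it is a 15-fold lower number from compound 2 to compound 3 (1.18 log units; beyond the scatter).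

The change to compound 4 (`CCCn1c(=O)n(CCOC)c(=O)c2[nH]cnc21`) is methoxy in place of dimethylamino on a saturated chain carbon, two bonds along the chain from an aromatic nitrogen. For the measured compounds named here, no measured pair makes this exact swap. Going by the values given here, the only large steps involve carboxy, as in a 26-fold higher number from compound 1 to compound 2 (1.41 log units; beyond the scatter), and methoxy is not that group. The closer guide is a 1.7-fold higher number from compound 1 to compound 3 (0.23 log units; within the scatter), a swap of chain groups that left the number within the scatter. No step beyond the scatter is therefore expected in this assay. The estimate amounts to a 1.4-fold lower number from compound 3 to compound 4 (0.13 log units; within the scatter). For compound 4 the estimated value is 2000 nM, with an expected range of 700 nM to 6000 nM.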

Compound 4, half-maximal effective concentration: 700 nM
Estimate against measurement, compound 4: 2.9-fold (0.46 log units) above; the range from low to high includes it.
By their numbers in this assay, from the lowest: compound 4; then compounds 1 and 3 (each within the scatter of the next); then compound 2.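

In this assay, this place responds to a swap that leaves the counted hydrogen-bond donors, acceptors and net charge unchanged: 2-methoxyethyl and 2-(dimethylamino)ethyl are told apart beyond the scatter (a 3.9-fold lower number from compound 3 to compound 4 (0.59 log units; beyond the scatter)). Compound 4 also separates from the chain of compound 1 (a 2.3-fold lower number from compound 1 to compound 4 (0.36 log units; beyond the scatter)) and lies much further from the carboxy chain (a 59-fold lower number from compound 2 to compound 4 (1.77 log units; beyond the scatter)), so a chain at this place now gives a lower number than compound 1 rather than only matching it or giving a higher one. Nothing at hand explains the step from dimethylamino to methoxy.

Open, as far as these compounds go, is whether the lower number belongs to the ether oxygen itself, which a hydroxy group or a simple ethyl ether at the chain end could test. Also open, from the compounds shown here alone, is how far it depends on chain length, which a 3-methoxypropyl chain could test.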